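Swapping methyl for phenyl on a sulfur across two related cores

A few compounds are considered here, and "the series" means these few. Any claim that something is new, unique, unknown or untested is made for them only; others in the source may bear on it.

Compound 1 `CNC1=C(SC)C(=O)c2ncccc2C1=O` is the starting point. In an ADME assay on cells (T-cell, Homo sapiens) for antiproliferative activity, read by MTT assay, with a stated time of 48 h (on this read-out lower numbers stand for stronger inhibition and higher numbers for weaker inhibition), compound 1 gives 19500 nM. Compound 2 `CNC1=C(Sc2ccccc2)C(=O)c2ncccc2C1=O` is the same molecule after one change, (phenyl in place of methyl on a sulfur), and in this assay compound 2 gives 12200 nM. The step of a 1.6-fold lower number from compound 1 to compound 2 (0.20 log units; within the scatter) is thus small.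

Compound 3 `CNC1=C(SC)C(=O)c2cccnc2C1=O` has the same atoms as compound 1 joined differently; how its core differs from the core of compound 1 is not broken down here. In this assay compound 3 gives 7570 nM, the lowest of the three numbers.

Compound 4 `CNC1=C(Sc2ccccc2)C(=O)c2cccnc2C1=O` has not yet been measured. It stands to compound 3 as compound 2 stands to compound 1, through (phenyl in place of methyl on a sulfur), at a place described in the same words, so this is the same change made on the other core. Within the data shown here, because the only measured instance of this change was a 1.6-fold lower number from compound 1 to compound 2 (0.20 log units; within the scatter), a step of similar size is expected, a 1.6-fold lower number from compound 3 to compound 4 (0.21 log units; within the scatter). On that basis compound 4 is estimated at 4700 nM, expected to fall between 2000 nM and 11000 nM.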

Compound 4, half-maximal inhibitory concentration: 6910 nM
The estimate for compound 4 lay 1.5-fold (0.17 log units) below the measured number, within the range that was stated.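

In this assay, putting phenyl in place of methyl on the sulfur gives a 1.1-fold lower number from compound 3 to compound 4 (0.04 log units; within the scatter), so on this second core the change cannot be told apart from the ordinary spread of repeated measurements. As far as these data can tell, the change behaves alike on the two cores: the same change on two cores in this assay, a 1.6-fold lower number (0.20 log units; within the scatter) from compound 1 to compound 2 and a 1.1-fold lower number (0.04 log units; within the scatter) from compound 3 to compound 4, 1.5-fold (0.16 log units) apart, within the scatter of two such steps. Among these compounds, this shows that in these two pairs the change makes no step large enough to read, but it does not show that the change is without effect in general, and two small steps give no rule for what it would do on a further core.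

The compounds shown leave open whether a different group on this sulfur, such as a longer chain like butyl, or a phenyl carrying an amine or a carboxylic acid, would give a step beyond the scatter. They also leave open whether the two cores would keep this picture in any read-out other than this assay.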